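The source may hold more compounds than are shown below. What is called first, only, known or untested is meant among the compounds shown, and "the series" means these compounds.

Measured compounds:
- compound 1 `O=C(Nc1cccc(-n2cc(-c3ccncc3)c(-c3ccc(Cl)c(O)c3)n2)c1)Nc1cccc(C(F)(F)F)c1`: 3310 nM
- compound 2 `COc1cc(-c2nn(-c3cccc(NC(=O)Nc4cccc(C(F)(F)F)c4)c3)cc2-c2ccncc2)ccc1Cl`: 1230 nM

In a functional assay on Hs-578T cells (Homo sapiens) for inhibition, read by sulforhodamine B assay, with a stated time of 48 h (on this read-out higher numbers stand for weaker inhibition of growth and lower numbers for stronger inhibition of growth), compound 2 gives the lowest of the two numbers, and a 2.7-fold lower number from compound 1 to compound 2 (0.43 log units; beyond the scatter). Compound 3 `COc1cc(-c2nn(-c3cccc(NC(=O)c4ccccc4)c3)cc2-c2ccncc2)ccc1Cl` differs from compound 2 by phenyl in place of (3-(trifluoromethyl)phenyl)amino on a carbonyl carbon. Within the data shown here, no measured step touches this part of the molecule; the only measured step concerns the oxygen on the aromatic ring, so it gives no guidance here. Removing the amide nitrogen and the trifluoromethyl group is a larger change than the measured one, and a weakening of inhibition is expected for compound 3, roughly a 4.1-fold higher number from compound 2 to compound 3 (0.61 log units; beyond the scatter), giving an estimated 5000 nM (range 1500 nM to 20000 nM).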

Compound 3, concentration for 50% growth inhibition: 1110 nM
Compound 3: the middle estimate sits 4.5-fold (0.65 log units) above what was measured; measured number below the stated range.
By their numbers in this assay, from the lowest: compounds 3 and 2 (each within the scatter of the next); then compound 1.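

In this assay, phenyl in place of (3-(trifluoromethyl)phenyl)amino on the carbonyl carbon gives a 1.1-fold lower number from compound 2 to compound 3 (0.04 log units; within the scatter). On this pair, the trifluoromethyl group and the amino nitrogen with its hydrogen can therefore go together without a change in growth inhibition beyond the scatter. Nothing available explains this result.

As far as these compounds go, the two groups left in a single step, so what each does alone remains open. Also open, from the compounds shown here alone, is whether a much smaller group on the carbonyl carbon, such as methyl, or a chain ending in an amine, would give a similar number.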